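A few compounds are considered here, and "the series" means these few. Any claim that something is new, unique, unknown or untested is made for them only; others in the source may bear on it.

Measured compounds:
compound 1 `O=C(CCc1cccc2c1B(O)OC2)Nc1ccc(F)cc1` — 650 nM
compound 2 `COc1ccccc1NC(=O)CCc1cccc2c1B(O)OC2` — 430 nM
compound 3 `O=C(CCc1cccc2c1B(O)OC2)Nc1cccc(-c2cccc(F)c2)c1` — 460 nM

In a functional assay on HCT-116 cells (Homo sapiens) for antiproliferative activity, read by MTT assay, with a stated time of 72 h (on this read-out lower numbers stand for stronger inhibition and higher numbers for weaker inhibition), compound 3 gives 460 nM, compound 2 gives 430 nM and compound 1 gives 650 nM. The three numbers sit within the usual scatter of one another, so compound 3 is not set apart from compound 2 or from compound 1 on this read-out. For the measured compounds named here, no step between two measured compounds that differ in a single place is available; all that can be said is that three different groups on the amide nitrogen return numbers in the same narrow band.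

The next compound is compound 4 `N#Cc1ccc(-c2cccc(NC(=O)CCc3cccc4c3B(O)OC4)c2)cc1`. Its difference from compound 3 is 4-cyanophenyl in place of 3-fluorophenyl on an aromatic carbon. The group that enters is larger by one heavy atom and brings one hydrogen-bond acceptor in its nitrile, where the group that leaves brought none. The measured compounds give no handle on what such a change does, and the spread seen so far across differing amide substituents is small. The expectation is therefore a step of no size beyond the scatter in this assay, in either direction, namely a 1.0-fold lower number from compound 3 to compound 4 (0.01 log units; within the scatter). Compound 4 is estimated at 450 nM, expected within 200 nM to 1000 nM.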

Compound 4, half-maximal inhibitory concentration: 410 nM
Compound 4: middle estimate off by 1.1-fold (0.04 log units), on the high side; the measured number falls inside the stated range.
By their numbers in this assay, from the lowest: compounds 4, 2, 3 and 1 (each within the scatter of the next).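

For the compounds shown here, the swap of 3-fluorophenyl for 4-cyanophenyl on an aromatic carbon, meta to a large group, gives in this assay a 1.1-fold lower number from compound 3 to compound 4 (0.05 log units; within the scatter), the first step that can be read at a single place. Going by these compounds alone, at this position, then, a nitrile with its hydrogen-bond acceptor and one more heavy atom can enter without a step beyond the scatter, where the earlier compounds offered only comparisons across differing amide substituents. No measurement at hand bears on why this step is as small as it is.

From the compounds shown here alone, with both aryl groups at this position carrying a single small substituent, it remains open whether the flat reading holds for an unsubstituted phenyl, or for a carboxylic acid or a primary amine in place of the nitrile. The compounds shown also leave open what a longer chain in place of the one that carries the amide would do, since that chain is the same in every compound here and no step at that place can be read.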